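The compounds below may be only part of what the source reports. "The series", "measured", "known", "first", "only" and "open" are said of these compounds alone.

Compound 1, `COc1ccc([C@H]2CC(=O)N(c3ccccc3)C2)cc1OC1CCCC1`. In a functional assay on HEK293 cells (Homo sapiens) for cytotoxicity (a lower number here means that less compound is tolerated, a higher number that more compound is tolerated), compound 1 gives > 10000 nM, which is a limit of the assay and not a number.
Compound 2, `COc1ccc([C@H]2CC(=O)N(c3cccc(N)c3C)C2)cc1OC1CCCC1`. In this assay compound 2 gives > 10000 nM, again a limit.
Compound 3, `COc1ccc([C@H]2CC(=O)N(c3ccccc3N)C2)cc1OC1CCCC1`. In this assay compound 3 gives > 10000 nM, also a limit.

Compound 3 therefore stands at the same limit as the two other compounds, and no ordering among the three can be read. The steps a step that the two limits leave unreadable from compound 1 to compound 2, a step that the two limits leave unreadable from compound 1 to compound 3 and a step that the two limits leave unreadable from compound 2 to compound 3 are all unreadable for this reason; what holds them together is the limit of > 10000 nM in this assay, at which 3 of the 3 values shown sit.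

Compound 4, `COc1ccc([C@H]2CC(=O)N(c3ccccc3C(F)(F)F)C2)cc1OC1CCCC1`, is not yet measured. It differs from compound 3 by trifluoromethyl in place of amino on an aromatic carbon. For the measured compounds named here, no measured step bears directly on this change, and the three measured steps give no size in either direction. Since every measured compound sits at the limit, the expectation for compound 4 is that it also stays at the limit, with a step that the limit leaves unreadable from compound 3 to compound 4 that is taken to be zero. Compound 4 is estimated at 20000 nM, within 10000 nM to 100000 nM.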

Compound 4, half-maximal cytotoxic concentration: > 10000 nM
Compound 4 was reported as a limit (the forecaster's own chance of this, stated with the estimate: 85%); the middle value does not contradict the limit.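

Compound 4 is reported only as a limit, as are compound 1, compound 2 and compound 3, so none of its steps to these compounds can be read: the limit of > 10000 nM in this assay, at which 4 of the 4 values shown sit.

The compounds shown leave open what concentration of any of the four is needed for a cytotoxic effect in this assay, and so whether the changes among them differ at all.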